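Trading a Bulky Aryl Group for a Small Vinyl Group

This account rests on a few compounds, and the source may have more. Where it says the series, first, only, none or still open, it means among the compounds named here.

Compound 3 `CC(C)(C)c1ccc(-c2ccc3c(C(=O)Nc4cccc(F)c4)cc(=O)[nH]c3c2)cc1` was tested in a functional assay on KYSE-410 cells (Homo sapiens) for antiproliferative activity, read by MTT assay, with a stated time of 72 h; a lower number here means a stronger inhibitor, a higher number a weaker inhibitor. In this assay compound 3 gives only a limit, > 20000 nM, so no number is known for it. Compound 1 `O=C(Nc1cc(F)cc(F)c1)c1cc(=O)[nH]c2cc(C(F)(F)F)ccc12` gives 17900 nM in this assay. Compound 2 `COc1ccc2c(C(=O)Nc3cc(F)cc(F)c3)cc(=O)[nH]c2c1` gives only a limit, > 20000 nM, in this assay. Going by the values given here, the one measured step, an at least 1.1-fold higher number from compound 1 to compound 2 (0.04 log units; that floor lies within the scatter), also swaps a single group on an aromatic carbon, and its floor sits within the scatter, as seen in the limit of > 20000 nM in this assay, at which 2 of the 3 values shown sit. Compound 4 `C=Cc1ccc2c(C(=O)Nc3cccc(F)c3)cc(=O)[nH]c2c1` differs from compound 3 by vinyl in place of 4-(tert-butyl)phenyl on an aromatic carbon. Among the compounds with values here, that change has no close precedent here, and all values so far are weak or limits, so no step beyond the scatter is expected. Compound 4 is expected to give about 20000 nM, within 8000 nM to 60000 nM. The expected step is a number no higher from compound 3 to compound 4 (the limit leaves the size open).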

Compound 4, half-maximal inhibitory concentration: 13600 nM
Compound 4: middle estimate off by 1.5-fold (0.17 log units), on the high side, within the range that was stated.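

Swapping 4-(tert-butyl)phenyl for vinyl on this aromatic carbon gives an at least 1.4-fold lower number from compound 3 to compound 4 (0.16 log units; that floor lies within the scatter). The smaller group, which carries no ring, thus yields a measured value where the larger group gave only a limit. Going by these compounds, this does not establish a real gain, and the true size of the step stays unknown, because the reading stops at a limit: the limit of > 20000 nM in this assay, at which 2 of the 4 values shown sit. Still open, on these data alone, is whether ethyl, an amine or a carboxylic acid on this same carbon would give a lower number in this assay.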